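The compounds below may be only part of what the source reports. "The series", "measured", "known", "first", "only" and "open" are said of these compounds alone.

Measured compounds:
compound 1 `O=CN1N=C(c2ccc(F)cc2)CC1c1cn(-c2ccccc2)nc1-c1ccc(Cl)c(Cl)c1` with 56.5%
compound 2 `Fc1ccc(C2=NN(c3ccccc3)C(c3cn(-c4ccccc4)nc3-c3ccc(Cl)c(Cl)c3)C2)cc1` with 55.7%
compound 3 `CCC(=O)N1N=C(c2ccc(F)cc2)CC1c1cn(-c2ccccc2)nc1-c1ccc(Cl)c(Cl)c1` with 63.4%

All three were tested in a functional assay on the whole organism (strain Wistar) for inhibition, with Rattus norvegicus as the target, read by paw edema, with stated times of 30 min and 60 min, at a dose of 50 mg/kg by the oral route; on this read-out lower numbers stand for less inhibition and higher numbers for more inhibition at the one dose given (going by the name of the read-out). Compound 3 carries the highest of the three numbers, yet the gaps to it are small: a number 6.9 percentage points higher from compound 1 to compound 3 (within the scatter) and a number 7.7 percentage points higher from compound 2 to compound 3 (within the scatter) both fall inside the scatter, so the three compounds cannot be told apart on these figures.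

Compound 4 `CC(=O)N1N=C(c2ccc(F)cc2)CC1c1cn(-c2ccccc2)nc1-c1ccc(Cl)c(Cl)c1` is the next compound, and it differs from compound 3 by hydrogen in place of methyl on a saturated chain carbon bound to a carbonyl carbon. Going by the values given here, the measured step closest in kind is the one from compound 1 to compound 3, where an ethyl replaced a hydrogen on a carbonyl carbon and the change was a number 6.9 percentage points higher from compound 1 to compound 3 (within the scatter). Cutting that chain back by one carbon is a smaller move than adding the whole ethyl, and the larger move already stayed within the scatter, so no step beyond the scatter is expected for compound 4 in this assay, which means a number 3.4 percentage points lower from compound 3 to compound 4 (within the scatter) is expected. Compound 4 is therefore estimated at 60%, with a range from 50% to 70%.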

Compound 4, a percentage reported as inhibition, in the whole organism at one dose (the size of the read-out at that dose, not a potency): 59.5%
Compound 4: the middle estimate sits 0.5 percentage points above what was measured; the measured number falls inside the stated range.
By their numbers in this assay, from the lowest: compounds 2, 1, 4 and 3 (each within the scatter of the next).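

With the acetyl group of compound 4, the chain on the carbonyl carbon can now be read in single-carbon moves in this assay: methyl in place of hydrogen (a number 3 percentage points higher from compound 1 to compound 4 (within the scatter)), then hydrogen in place of methyl going back from the propanoyl group (a number 3.9 percentage points lower from compound 3 to compound 4 (within the scatter)). Acetyl in place of phenyl on the amine nitrogen in a ring behaves no differently (a number 3.8 percentage points higher from compound 2 to compound 4 (within the scatter)), so neither change at this position separates the compounds on these figures. Nothing shown explains why these numbers sit so close together. Still open, as far as these compounds go, is whether a longer chain such as butanoyl, a branched chain such as isobutyryl, or an amine on that carbon would move the number beyond the scatter. A single dose also cannot show whether the compounds would separate at other doses.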